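Capping the acid: a methyl ester of compound 2

The source may report more compounds than this note shows. Statements on the series, on what has been measured and on what is new or still open speak of the compounds shown alone.

Of the compounds shown here, three have been tested in an assay for inhibition of hexokinase-2 (Homo sapiens), read by ADP-Glo, with a stated time of 45 min, in the presence of a further agent that is not named here; a lower number here means a stronger inhibitor, a higher number a weaker inhibitor. Compound 1 `O=C(N[C@H]1C(O)O[C@H](CO)[C@@H](O)[C@@H]1O)c1ccc(-c2ccccc2)cc1` gives 16000 nM, and compound 3 `O=C(N[C@H]1C(O)O[C@H](CO)[C@@H](O)[C@@H]1O)c1cccc(-c2ccccc2)c1` gives 3200 nM. Compound 2 `Cc1oc(S(=O)(=O)NC[C@H]2OC(O)[C@H](NC(=O)c3cccc(Br)c3)[C@@H](O)[C@@H]2O)cc1C(=O)O` gives 10 nM, the lowest number of the three; its gap to compound 3 and its larger gap to compound 1 both lie beyond the usual scatter, so compound 2 is the strongest inhibitor among the measured compounds.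

Compound 4 `COC(=O)c1cc(S(=O)(=O)NC[C@H]2OC(O)[C@H](NC(=O)c3cccc(Br)c3)[C@@H](O)[C@@H]2O)oc1C` has not yet been measured. It differs from compound 2 in a single place: methyl in place of hydrogen on an oxygen next to a carbonyl group. Read one bond further out, the carboxy group of compound 2 becomes a methoxycarbonyl group in compound 4.

Among the compounds with values here, no measured pair in this set shows this kind of change, so there is no direct guide to the size or direction of the step. Capping an acid as its methyl ester is a small change in atom count, yet it removes the acidic hydrogen that compound 2 carries. The step from compound 2 to compound 4 is expected to be a 4.0-fold higher number from compound 2 to compound 4 (0.60 log units; beyond the scatter), a modest loss of potency that may or may not exceed the scatter. Compound 4 is therefore estimated at 40 nM, within a range from 8 nM to 300 nM.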

Compound 4, half-maximal inhibitory concentration: 630 nM
Estimate against measurement, compound 4: 16-fold (1.20 log units) below, and the stated range ends below it.
By their numbers in this assay, from the lowest: compound 2; then compound 4; then compound 3; then compound 1.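

In this assay, within the data shown here, this is the first measured step of its kind, and putting methyl in place of the hydrogen on this oxygen gives a 63-fold higher number from compound 2 to compound 4 (1.80 log units; beyond the scatter) in a single change, a large step beyond the scatter. The position is therefore far from indifferent to a small edit: turning carboxy into methoxycarbonyl adds only one methyl, with the rest of the molecule unchanged, yet it clearly separates the two compounds. No measurement here bears on what lies behind the size of this step, which remains unexplained.

From the compounds shown here alone, the pair gives only two points at this position, so it remains open whether a primary carboxamide, an ethyl ester or a hydroxymethyl group in place of the carboxy group would sit close to compound 2, close to compound 4 or elsewhere. Going by these compounds, it is also open whether the same change would cost as much if the bromine on the benzamide part or the sulfonamide link of compound 2 were replaced, as a single pair cannot show how far this step carries over to other compounds.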